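The source may report more compounds than this note shows. Statements on the series, on what has been measured and on what is new or still open speak of the compounds shown alone.

Measured in an ADME assay on RAW264.7 cells (Mus musculus) for cytotoxicity, read by MTT assay, with a stated time of 24 h, in the presence of a further agent that is not named here (on this read-out lower numbers stand for stronger inhibition and higher numbers for weaker inhibition), each value being a limit and not a number:

Compound 1 `CCOc1ccc(C(O)C2OC(=O)c3c(OC)cc(OC)cc32)cc1`: > 40000 nM
Compound 2 `CCCCOc1ccc(C(O)C2OC(=O)c3c(OC)cc(OC)cc32)cc1`: > 40000 nM
Compound 3 `CCCCCCOc1ccc(C(O)C2OC(=O)c3c(OC)cc(OC)cc32)cc1`: > 40000 nM

Compound 3 offers no exact number, only the limit > 40000 nM. It shares that position with the other two compounds: the limit of > 40000 nM in this assay, at which 3 of the 3 values shown sit.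

Compound 4 `CCC(C)Oc1ccc(C(O)C2OC(=O)c3c(OC)cc(OC)cc32)cc1` keeps the rest of compound 3 and differs by sec-butyl in place of hexyl on an oxygen on an aromatic ring. In words, sec-butyl stands in place of hexyl on an oxygen on an aromatic ring.

The measured steps that bear on this change are those that alter the chain: a step that the two limits leave unreadable from compound 1 to compound 2, a step that the two limits leave unreadable from compound 2 to compound 3 and a step that the two limits leave unreadable from compound 1 to compound 3. None of them has a readable size, so they offer no measured direction. For the measured compounds named here, no measured compound carries sec-butyl.

The expectation rests on compound 3 and its neighbours all sitting at one limit, as the limit of > 40000 nM in this assay, at which 3 of the 3 values shown sit, shows. No step beyond the usual scatter is expected, and the estimated step is a step that the limit leaves unreadable from compound 3 to compound 4. For compound 4 the expected value is 50000 nM, with an estimated range from 20000 nM to 100000 nM.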

Compound 4, half-maximal inhibitory concentration: > 40000 nM
Compound 4: only a limit was reported (the forecaster's own chance of this, stated with the estimate: 85%); the middle value is on the limit's open side.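

In this assay, no step can be read between compound 4 and compound 1, compound 2 or compound 3, as each value is a limit and not a number: the limit of > 40000 nM in this assay, at which 4 of the 4 values shown sit.

The compounds shown leave open whether ethyl, butyl, hexyl and sec-butyl on this oxygen differ at all in this read-out.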